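The source may hold more compounds than are shown below. What is called first, only, known or untested is meant among the compounds shown, and "the series" means these compounds.

Measured so far:
compound 1, `CC(/C=N/N(C)c1ccc([N+](=O)[O-])cc1)=N\NC(=O)c1cc([N+](=O)[O-])cc([N+](=O)[O-])c1`: 39000 nM
compound 2, `CC(/C=N/Nc1ccc([N+](=O)[O-])cc1)=N\NC(=O)c1ccccc1C`: > 100000 nM

In an ADME assay on J774 cells (Mus musculus, strain BALB/c) for cytotoxicity, read by resazurin assay, with a stated time of 72 h (on this read-out higher numbers stand for lower toxicity in this test and lower numbers for higher toxicity in this test), compound 1 gives 39000 nM. Compound 2 in this assay gives > 100000 nM, which is a limit of the assay and not a number. Compound 2 therefore stands at the limit of > 100000 nM in this assay, at which 1 of the 2 values shown sits, and its distance from compound 1 cannot be sized.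

Compound 3, `CC(/C=N/Nc1ccc([N+](=O)[O-])cc1)=N\NC(=O)c1cccc(C)c1`, differs from compound 2 by 3-methylphenyl in place of 2-methylphenyl on a carbonyl carbon. Among the measured compounds shown here, no measured pair shows a step, so the size of this change is unknown; nothing beyond the scatter is expected in either direction. The expected step is a number no higher from compound 2 to compound 3 (the limit leaves the size open). Compound 3 is estimated at 100000 nM, within 40000 nM to 250000 nM, most likely reported again as a limit.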

Compound 3, half-maximal cytotoxic concentration: > 100000 nM
Compound 3 ended at the assay's limit; the forecaster's own chance of this, stated with the estimate: 60%; the middle value lies on the limit itself.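

No step can be read from compound 2 to compound 3, since both results are limits of the assay and not numbers: the limit of > 100000 nM in this assay, at which 2 of the 3 values shown sit. As far as these compounds go, whether 3-methylphenyl in place of 2-methylphenyl on a carbonyl carbon changes toxicity in this test stays open.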